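The compounds below may be only part of what the source reports. "The series", "measured", "known", "first", "only" and "open" are said of these compounds alone.

Compound 1 `COc1ccc(Cc2cnc(CCc3ccc(-c4ccccc4C(=O)O)cc3)[nH]2)cc1` was tested in an in vitro functional assay on cells for agonist activity at Bombesin receptor subtype-3 (Homo sapiens), read by luminescence and calcium flux (on this read-out higher numbers stand for an effect only at larger amounts of compound and lower numbers for an effect already at smaller amounts), and gave 5360 nM. Of the two compounds measured, compound 1 stands at the highest number, so its effect appears only at the larger amounts. The other measured compound, compound 2 `CCC(C)(C)Cc1c[nH]c(CCc2ccc(-c3ccccc3C(=O)O)cc2)n1`, carries a 2,2-dimethylbutyl group on the shared core where compound 1 carries a 4-methoxybenzyl group, and in this assay compound 2 gives 25 nM, a much lower number that lies well beyond the scatter from compound 1.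

Within the data shown here, compound 3 `N#Cc1cccc(Cc2cnc(CCc3ccc(-c4ccccc4C(=O)O)cc3)[nH]2)c1` keeps the core of compound 1 and changes only one group: 3-cyanophenyl in place of 4-methoxyphenyl on a saturated chain carbon bound to an aromatic carbon. Among the measured compounds shown here, no measured pair shows this exact change, so what it does to the number is not known from these data. Both compound 1 and compound 3 keep an aromatic ring at this place, while compound 2 has a branched chain there, so the large drop seen for compound 2 need not carry over.

Compound 3 is expected to stay close to compound 1, with the step of a 1.8-fold lower number from compound 1 to compound 3 (0.25 log units; within the scatter) estimated as small or none beyond the scatter. The estimate for compound 3 in this assay is 3000 nM, within a range from 700 nM to 13000 nM.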

Compound 3, half-maximal effective concentration: 812 nM
Beside the measured number, compound 3's estimate is 3.7-fold (0.57 log units) above it, within the range that was stated.
By their numbers in this assay, from the lowest: compound 2; then compound 3; then compound 1.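

Swapping one aromatic group for another here is not a neutral exchange: the step is a 6.6-fold lower number from compound 1 to compound 3 (0.82 log units; beyond the scatter), even though 4-methoxyphenyl and 3-cyanophenyl have the same count of heavy atoms, the same six-membered aromatic ring and the same counts of hydrogen-bond donors and acceptors. The earlier compounds shown here differed far more at this place, an aromatic group against a branched chain, so they could not show that the number also responds to what the aromatic ring carries. Even so, compound 3 at 812 nM stays well above compound 2 at 25 nM, so keeping a substituted aromatic ring here does not by itself reach the low number of the branched chain, and no measurement on hand explains the shift seen with the new group.

The change removes a methoxy group and adds a nitrile at a different ring position in a single step, so these compounds cannot say which of those matters. A plain phenyl group at this place would help separate the loss of the methoxy group from the gain of the nitrile, while a 2,2-dimethylpropyl group would test how far the branched chain can be shortened.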